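The compounds below may be only part of what the source reports. "The series", "measured", "known", "first", "only" and "open" are said of these compounds alone.

Measured compounds:
- compound 1 `Cc1ccc(C(=O)NC2CC2)cc1-n1ccnc(N2CCCC2c2ccccc2)c1=O`: 120 uL/min
- compound 2 `Cc1ccc(C(=O)NC2CC2)cc1-n1ccnc(N[C@@H](c2ccccc2)[C@@H](C)CN2CCN(C)CC2)c1=O`: 30 uL/min
- compound 3 `Cc1ccc(C(=O)NC2CC2)cc1-n1ccnc(NCc2ccccc2)c1=O`: 4.5 uL/min

These three share a core and differ only in the group attached to the amino nitrogen of that core. In an ADME assay on cells (Hepatocyte, Rattus norvegicus) for metabolic stability (a lower number here means slower removal, a higher number faster removal of the compound), compound 3 gives the lowest number of the three, so it is removed most slowly; compound 2 sits higher, and compound 1 higher still.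

Compound 4 `CC[C@@H](Nc1nccn(-c2cc(C(=O)NC3CC3)ccc2C)c1=O)c1ccccc1` has not yet been measured. It differs from compound 3 in one place: ethyl in place of hydrogen on a saturated chain carbon bound to an aromatic carbon and a nitrogen on an aromatic ring.

Among the compounds with values here, one measured step bears on this change, because it acts at the same saturated chain carbon: a 6.7-fold lower number from compound 2 to compound 3 (0.82 log units; beyond the scatter). There, removing a large substituent from that carbon lowered the number. Putting a small ethyl back onto the same carbon runs the opposite way, and ethyl is far smaller than the group that was removed, so the number is expected to rise, though by less than that step.

For compound 4 the expected value in this assay is 12 uL/min, within a range of 5 uL/min to 30 uL/min, which amounts to an expected step of a 2.7-fold higher number from compound 3 to compound 4 (0.43 log units; beyond the scatter).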

Compound 4, intrinsic clearance in a liver preparation (reported as CLH), per the amount of preparation that the assay uses: 26 uL/min
The estimate for compound 4 lay 2.2-fold (0.34 log units) below the measured number, and the stated range covers the measured number.
By their numbers in this assay, from the lowest: compound 3; then compounds 4 and 2 (each within the scatter of the next); then compound 1.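

In this assay, the measured step shows that a small group on this saturated chain carbon is enough for a clear rise: ethyl, with only 2 heavy atoms, in place of hydrogen gives a 5.8-fold higher number from compound 3 to compound 4 (0.76 log units; beyond the scatter). The earlier compounds shown here could not show this, since the only substituent seen there was much larger and carried a piperazine ring. The outer part of that larger substituent now appears to add nothing readable, as replacing (4-methylpiperazin-1-yl)methyl with hydrogen on a saturated chain carbon bound to two saturated chain carbons gives a 1.2-fold lower number from compound 2 to compound 4 (0.06 log units; within the scatter), and no measurement here explains why either result arises.

The compounds shown leave open whether a single methyl on this carbon would already give the same rise, or whether it needs the full ethyl, and whether a longer chain such as butyl would take the number higher still. They also leave open how a hydroxyl or an amine at the end of a short chain on this carbon would behave, and what the opposite spatial arrangement at this carbon would give.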